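This account rests on a few compounds, and the source may have more. Where it says the series, first, only, none or still open, it means among the compounds named here.

Measured in a functional assay on HEK293 cells for agonist activity at Free fatty acid receptor 1 (Homo sapiens), read by HTRF and inositol phosphate accumulation, with a stated time of 60 min; a higher number here means that more compound is needed for the effect, a lower number that less compound is needed:
compound 1 `COc1cc(O[C@H]2C[C@H](OC)C2)cc(-c2ccc3c(c2)CC[C@H]([C@@H]2C[C@H]2C(=O)O)O3)c1F`: only a limit, > 10000 nM
compound 2 `COc1cc(OC2CCC2)nc(-c2ccc3c(c2)CC[C@H](CCC(=O)O)O3)c1F`: only a limit, > 10000 nM
compound 3 `COc1cc(O[C@H]2C[C@H](OC)C2)nc(-c2ccc3c(c2)CC[C@H](CCC(=O)O)O3)c1F`: only a limit, > 10000 nM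

None of the three values is a number; all sit at the limit of > 10000 nM in this assay, at which 3 of the 3 values shown sit. From compound 3 to compound 2 the change is hydrogen in place of methoxy on a saturated ring carbon, and the step that the two limits leave unreadable from compound 3 to compound 2 is unreadable with both ends at the limit.

Compound 4 `COc1cc(OC2CCC2)cc(-c2ccc3c(c2)CC[C@H]([C@@H]2C[C@H]2C(=O)O)O3)c1F` is not yet measured. It differs from compound 1 by hydrogen in place of methoxy on a saturated ring carbon, the same change at the same place as from compound 3 to compound 2. The difference between the cores of compound 1 and compound 3 is not broken down here.

For compound 4 a step that the limit leaves unreadable from compound 1 to compound 4 in this assay is expected. This rests on compound 1 sitting at > 10000 nM and on the unreadable step of the same change between compound 3 and compound 2. Compound 4 is expected at 20000 nM, between 5000 nM and 100000 nM, most likely again reported only as a limit.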

Compound 4, half-maximal effective concentration: > 10000 nM
Compound 4 was reported as a limit (the forecaster's own chance of this, stated with the estimate: 85%); the middle value lies beyond the limit too.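

Compound 1 and compound 4 both stand only as limits, so no step can be read between them: the limit of > 10000 nM in this assay, at which 4 of the 4 values shown sit.

The compounds shown leave open whether hydrogen in place of methoxy on a saturated ring carbon changes the effective concentration at all, in either core.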